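A Cyclic Amide Replaces the Chain in a Weak Binder

A few compounds are considered here, and "the series" means these few. Any claim that something is new, unique, unknown or untested is made for them only; others in the source may bear on it.

Compound 2, with structure `CC(C)(C)c1ccc(C(=O)N2CCC3(CC2)C(=O)N(CC(=O)NCCCCNS(C)(=O)=O)CN3c2ccccc2)cc1`, is a weak binder in an assay on HEK293 cells for displacement of a labelled ligand from NPC1-like intracellular cholesterol transporter 1 (Homo sapiens) (a lower number here means a stronger inhibitor, a higher number a weaker inhibitor), giving 4500 nM. It differs from compound 1, `CC(C)(C)OC(=O)NCCCNC(=O)CN1CN(c2ccccc2)C2(CCN(C(=O)c3ccc(C(C)(C)C)cc3)CC2)C1=O`, only at the end of its side chain, and compound 1 gives 4500 nM in this assay. Among the measured compounds shown here, the single measured step, no change at the digits printed from compound 1 to compound 2 (within the scatter), shows that exchanging one group for another at the far end of this chain left the binding where it was, within the scatter. Compound 3, `CC(C)(C)c1ccc(C(=O)N2CCC3(CC2)C(=O)N(CC(=O)N2CCCC(C(N)=O)C2)CN3c2ccccc2)cc1`, takes a larger step from compound 2: the change is 3-carbamoylpiperidin-1-yl in place of (4-(methanesulfonamido)butyl)amino on a carbonyl carbon. For the measured compounds named here, only the step from compound 1 to compound 2 bears on this, and it was flat; it concerned the end of the chain rather than its replacement by a ring, so it gives weak guidance. The expected step is therefore no change at the digits printed from compound 2 to compound 3 (within the scatter), that is, no change beyond the scatter, with a wide margin for the untested ring. Compound 3 is estimated at 4500 nM in this assay, within a range from 1500 nM to 13000 nM.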

Compound 3, half-maximal inhibitory concentration: 16900 nM
Beside the measured number, compound 3's estimate is 3.8-fold (0.57 log units) below it, and the stated range ends below it.
By their numbers in this assay, from the lowest: compounds 1 and 2 (each within the scatter of the next); then compound 3.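

In this assay, this position proves sensitive to the group attached to the carbonyl carbon: replacing the open (4-(methanesulfonamido)butyl)amino chain with a 3-carbamoylpiperidin-1-yl ring gives a 3.8-fold higher number from compound 2 to compound 3 (0.57 log units; beyond the scatter), even though 10 heavy atoms leave and 9 enter. The comparison with the other open chain, (3-((tert-butoxycarbonyl)amino)propyl)amino, points the same way, with a 3.8-fold higher number from compound 1 to compound 3 (0.57 log units; beyond the scatter), so a ring in this place gives a weaker inhibitor than either chain, whereas changing the far end of the chain gave only no change at the digits printed from compound 1 to compound 2 (within the scatter). No measurement here explains why the ring gives the weaker result.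

The ring and its carbamoyl group arrive together, so the compounds shown leave open which of them matters, a question that a plain piperidin-1-yl group in the same place could help to separate. From the compounds shown here alone, it also remains open whether a chain ending in an amine or a carboxylic acid would stay level with compound 1 or shift the number in either direction.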